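The source may report more compounds than this note shows. Statements on the series, on what has been measured and on what is new or still open speak of the compounds shown alone.

Measured compounds:
Compound 1, `COc1ccc(/C=C\C(=O)O)c(OCc2cn(-c3ccccc3)nn2)c1CC=C(C)C`: 40500 nM
Compound 2, `COc1ccc(/C=C\C(=O)O)c(OCc2cn(-c3cccc([N+](=O)[O-])c3)nn2)c1CC=C(C)C`: "not determined" (no result reported)
Compound 3, `COc1ccc(/C=C\C(=O)O)c(OCc2cn(-c3cccc(C#N)c3)nn2)c1CC=C(C)C`: "not determined" (no result reported)

All three share one core and differ only in the group carried on an aromatic nitrogen of the five-membered ring. In a functional assay on A549 cells (Homo sapiens) for cytotoxicity, read by MTT assay, with a stated time of 24 h (on this read-out higher numbers stand for weaker inhibition and lower numbers for stronger inhibition), compound 1 gives 40500 nM, a weak effect on cell viability. For compound 2 the entry reads "not determined" (no result reported) and for compound 3 it reads "not determined" (no result reported), so compound 1 stands alone: its value is the only one shown, and nothing can be said of how the other two compare with it.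

Compound 4, `COc1ccc(/C=C\C(=O)O)c(OCc2cn(-c3cccnc3Cl)nn2)c1CC=C(C)C`, has not been measured. Set against compound 1, the difference is 2-chloropyridin-3-yl in place of phenyl on an aromatic nitrogen. Within the data shown here, no pair of measured compounds shows what such a change does in this setting, so there is no measured step to lean on. The plain expectation is therefore a move of no more than the usual scatter, in either direction. The estimated step is a 1.0-fold lower number from compound 1 to compound 4 (0.01 log units; within the scatter). Compound 4 is expected at about 40000 nM, most likely between 15000 nM and 100000 nM, with a real chance that this assay reports only a limit rather than a number.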

Compound 4, half-maximal inhibitory concentration: 5600 nM
Compound 4: the middle estimate sits 7.1-fold (0.85 log units) above what was measured; measured number outside the range, below it.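

In this assay, among these compounds, the group on an aromatic nitrogen of the five-membered ring proves able to shift the read-out: 2-chloropyridin-3-yl in place of phenyl gives a 7.2-fold lower number from compound 1 to compound 4 (0.86 log units; beyond the scatter), a step beyond the usual scatter and the only measured step at this place. The change brings in a ring nitrogen and a chlorine together, so this one step belongs to the whole new group and cannot be divided between those two atoms. Nothing measured here gives a reason for the step.

Whether the ring nitrogen, the chlorine or the two together account for the lower number stays open, and pyridin-3-yl and 2-chlorophenyl, each holding only one of the two, would separate them. As far as these compounds go, compound 2 and compound 3 have no number to set beside these values, so it also stays open how other groups on the phenyl ring, such as an amine, would read in this assay.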